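The source may hold more compounds than are shown below. What is called first, only, known or untested is meant among the compounds shown, and "the series" means these compounds.

Three compounds sharing one core were measured in an assay on HEK293 cells for displacement of a labelled ligand from D(4) dopamine receptor (Homo sapiens), read by scintillation counting, with a stated time of 90 min; on this read-out higher numbers stand for weaker inhibition and lower numbers for stronger inhibition. Compound 1 `Cc1cccc(NC(=O)CN2CCN(c3cccc4ccccc34)CC2)c1` gives 1.65 nM, and compound 3 `Cc1cccc(NC(=O)CN2CCC(c3ccccc3)CC2)c1` gives 1.4 nM. Compound 2 `Cc1cccc(NC(=O)CN2CCN(c3ccc(Cl)cn3)CC2)c1` gives 12.5 nM, the highest of the three numbers; its gaps to compound 1 and to compound 3 both lie beyond the scatter, so compound 2 is the weakest binder of the three. Compound 4 `Cc1cccc(NC(=O)CN2CCN(c3ccccn3)CC2)c1` has not been measured. It differs from compound 2 by hydrogen in place of chloro on an aromatic carbon. For the measured compounds named here, no measured pair shows this change, so the data give no step to lean on. The step of a 1.3-fold higher number from compound 2 to compound 4 (0.11 log units; within the scatter) is expected to stay within the scatter, or at most to weaken binding slightly. In this assay compound 4 is estimated at 16 nM, between 6 nM and 45 nM.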

Compound 4, inhibition constant: 1.89 nM
Compound 4: middle estimate off by 8.5-fold (0.93 log units), on the high side; measured number outside the range, below it.
By their numbers in this assay, from the lowest: compounds 3, 1 and 4 (each within the scatter of the next); then compound 2.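

In this assay, going from 5-chloropyridin-2-yl to pyridin-2-yl gives a 6.6-fold lower number from compound 2 to compound 4 (0.82 log units; beyond the scatter). The earlier compounds shown here offered no step at this position; this one ties the higher number of compound 2 to the chloro group rather than to the pyridin-2-yl ring that carries it. Nothing at hand gives a reason for this step. As far as these compounds go, whether a fluoro, methyl or methoxy group at this place would read like chloro or like hydrogen stays open. So does whether removing chloro gives a similar step on another ring.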